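This account rests on a few compounds, and the source may have more. Where it says the series, first, only, none or still open, it means among the compounds named here.

Working notes on the series.

Compound 1 `COC1NC(=S)NC(c2ccccc2)=C1CC(=O)O` is tested in a functional assay on the whole organism for inhibition, with Rattus norvegicus as the target, read by paw edema, with stated times of 1 h and 3 h, at a dose of 10 mg/kg by the oral route (a lower number here means less inhibition, a higher number more inhibition at the dose given (going by the name of the read-out)), where compound 1 gives 32%. Compound 2 `O=C(O)CC1=C(c2ccccc2)N=C(S)NC1c1cccs1` in this assay gives 21%, and compound 3 `O=C(O)CC1=C(c2ccc(Cl)cc2)NC(=S)NC1c1ccc(-c2cccs2)cc1` gives 16%. Among the three numbers so far, compound 1 stands highest: compound 2 comes nearest, with a lower number, a gap beyond the scatter, and compound 3 lies furthest, with a still lower number, also beyond the scatter. No pair among these three differs in a single place, so none of these gaps can be tied to one structural change, and the values simply show where each compound falls.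

Compound 4 `COC1NC(=S)NC(c2ccc(C)cc2)=C1CC(=O)O` has not been measured. It differs from compound 1 in one place: methyl in place of hydrogen on an aromatic carbon. Within the data shown here, the set so far holds no compound in which a methyl sits on that ring in this way, so there is no measured step to lean on. The step from compound 1 to compound 4 in this assay is expected to be small, no larger than the scatter, and without a clear direction; the estimate a number 2 percentage points higher from compound 1 to compound 4 (within the scatter) reflects that. For compound 4, the expected value in this assay is 34%, with a range from 20% to 48%.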

Compound 4, a percentage reported as inhibition, in the whole organism at one dose (the size of the read-out at that dose, not a potency): 33%
The estimate for compound 4 lay 1 percentage points above the measured number; the measured number falls inside the stated range.
By their numbers in this assay, from the lowest: compounds 3 and 2 (each within the scatter of the next); then compounds 1 and 4 (each within the scatter of the next).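

Methyl in place of hydrogen on an aromatic carbon, para to a large group, gives a number 1 percentage points higher from compound 1 to compound 4 (within the scatter) in this assay, and this is the first step in the series that can be tied to one change. On this six-membered aromatic ring of carbon only, the entry of one carbon, with no ring and no hydrogen-bond donors or acceptors, leaves the paired compounds inseparable at the dose given, so this position accepts a methyl without a readable change in inhibition. No measurement at hand accounts for this outcome, and the pair gives the size of the read-out at one dose, not a potency.

Open, on these data alone, is whether an amine, a hydroxyl or a longer chain such as propyl at this same place would also stay within the scatter, as one methyl step says nothing about groups of other kinds or greater size. Also open, as far as these compounds go, is whether methyl in place of hydrogen on the phenyl ring of compound 2 would give a step of similar size on that different core.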